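Swapping Methoxy for Carboxy in a Paw Edema Series

A few compounds are considered here, and "the series" means these few. Any claim that something is new, unique, unknown or untested is made for them only; others in the source may bear on it.

Within the data shown here, compound 2 `COc1ccc(NCC2C(=O)N(C(=O)c3cc4ccccc4oc3=O)N=C2C)cc1` holds the lower of the two numbers measured so far. In a functional assay on the whole organism for inhibition, with Rattus norvegicus as the target, read by paw edema, with stated times of 1 h and 6 h, at a dose of 0.03 mg/kg by the oral route (on this read-out lower numbers stand for less inhibition and higher numbers for more inhibition at the one dose given (going by the name of the read-out)), compound 2 gives 55.1%, while compound 1 `CC1=NN(C(=O)c2cc3ccccc3oc2=O)C(=O)C1CNc1ccc(S(N)(=O)=O)cc1` gives 77.9%. Among the measured compounds shown here, the only measured step, a number 22.8 percentage points lower from compound 1 to compound 2 (beyond the scatter), is a modest drop beyond the usual scatter, showing that the group on this aromatic carbon matters for the read-out. Compound 3 `CC1=NN(C(=O)c2cc3ccccc3oc2=O)C(=O)C1CNc1ccc(C(=O)O)cc1` has not been measured; it differs from compound 2 by carboxy in place of methoxy on an aromatic carbon. The step from sulfamoyl to methoxy is the one that bears on this change, and carboxy resembles sulfamoyl more than methoxy in what it carries, as the counted difference shows. No direct measurement of carboxy exists here. A rise is therefore expected, estimated as a number 12.9 percentage points higher from compound 2 to compound 3 (beyond the scatter), recovering part of the earlier drop. Compound 3 is expected to give about 68%, within a range from 50% to 85%.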

Compound 3, a percentage reported as inhibition, in the whole organism at one dose (the size of the read-out at that dose, not a potency): 72.6%
For compound 3 the middle estimate is 4.6 percentage points below the measured one; the range from low to high includes it.
By their numbers in this assay, from the lowest: compound 2; then compounds 3 and 1 (each within the scatter of the next).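

In this assay, among these compounds, placing carboxy where methoxy stood on this aromatic carbon gives a number 17.5 percentage points higher from compound 2 to compound 3 (beyond the scatter), so sulfamoyl is no longer the only group seen to stand clear of methoxy at this position. Carboxy and sulfamoyl, however, cannot be told apart here, with a number 5.3 percentage points lower from compound 1 to compound 3 (within the scatter), even though they differ in their atoms. No measurement at hand gives a reason for these numbers.

The compounds shown leave open how an amine, a nitrile or a methyl ester would fare on this same aromatic carbon, which would show how widely the result holds beyond these three groups. All three numbers also come from a single dose, so they describe the size of the effect at that dose and cannot rank the compounds by potency.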